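Swapping nitro for trifluoromethyl on the aryl ring

This account rests on a few compounds, and the source may have more. Where it says the series, first, only, none or still open, it means among the compounds named here.

Measured in a functional assay on HCT-116 cells (Homo sapiens) for inhibition, read by MTT assay, with a stated time of 48 h (on this read-out lower numbers stand for stronger inhibition and higher numbers for weaker inhibition), so far
compound 1 `COc1cc(-c2nccn3cc(-c4ccc(Cl)cc4)nc23)cc(OC)c1OC`: 351 nM
compound 2 `COc1cc(-c2nccn3cc(-c4ccc5[nH]ccc5c4)nc23)cc(OC)c1OC`: 23 nM
compound 3 `COc1cc(-c2nccn3cc(-c4ccc([N+](=O)[O-])cc4)nc23)cc(OC)c1OC`: > 10000 nM (a limit)

Compound 3 gives only a limit (> 10000 nM) and no number. The next compound, compound 4 `COc1cc(-c2nccn3cc(-c4ccc(C(F)(F)F)cc4)nc23)cc(OC)c1OC`, has not yet been measured. It differs by one change (trifluoromethyl in place of nitro on an aromatic carbon), trifluoromethyl in place of nitro on an aromatic carbon. Two large measured steps bear on this: an at least 28-fold higher number from compound 1 to compound 3 (1.45 log units; beyond the scatter) with nitro in place of chloro, and an at least 430-fold higher number from compound 2 to compound 3 (2.63 log units; beyond the scatter) with 4-nitrophenyl in place of 1H-indol-5-yl. Both show nitro on the weak side, so a large change toward a lower number is expected (an at least 6.6-fold lower number from compound 3 to compound 4 (0.82 log units; beyond the scatter)). Compound 1 (351 nM) serves as the nearest guide. Compound 4 is estimated in this assay at 1500 nM within an expected range of 300 nM to 8000 nM.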

Compound 4, half-maximal inhibitory concentration: > 10000 nM
Compound 4: no number, only a limit; the forecaster's own chance of this, stated with the estimate: 15%; middle value at least 6.6-fold (0.82 log units) away from the limit.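

In this assay compound 4, like compound 3, gives only a limit, and the step between them cannot be read: the limit of > 10000 nM in this assay, at which 2 of the 4 values shown sit. Trifluoromethyl therefore sits on the weak side with nitro, giving an at least 28-fold higher number from compound 1 to compound 4 (1.45 log units; beyond the scatter) and an at least 430-fold higher number from compound 2 to compound 4 (2.63 log units; beyond the scatter). The loss seen with compound 3 is thus not confined to nitro.

From the compounds shown here alone, how far compound 3 and compound 4 lie beyond the limit remains open. So does whether an amine, a hydroxyl or a methoxy group at this place would match chloro or the 1H-indol-5-yl ring.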